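Removing a Methyl from an Alkyne: Three Limits, One Prediction

The compounds below may be only part of what the source reports. "The series", "measured", "known", "first", "only" and "open" are said of these compounds alone.

Three compounds were tested in a functional assay on HCT-116 cells (Homo sapiens) for cytotoxicity, with a stated time of 3 days; on this read-out higher numbers stand for weaker inhibition and lower numbers for stronger inhibition. Compound 1, with the structure `CC#CC1=Nc2ccccc2C(C)(C)O1`, carries a prop-1-yn-1-yl group on one core. Compound 2, with the structure `CC#Cc1nc(C(=O)OCC)cs1`, carries the same prop-1-yn-1-yl group on a different core, and compound 3, with the structure `C#Cc1nc(C(=O)OCC)cs1`, is its ethynyl counterpart. How the two cores differ is not broken down here.

In this assay compound 1 gives > 40000 nM, which is a limit of the assay rather than a number. Compound 2 gives > 40000 nM, likewise a limit. Compound 3 gives > 40000 nM, again a limit. All three values therefore sit at the limit of > 40000 nM in this assay, at which 3 of the 3 values shown sit.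

The change from compound 2 to compound 3 is hydrogen in place of methyl on a triple-bonded carbon. Because both values are limits, the step that the two limits leave unreadable from compound 2 to compound 3 cannot be read.

Compound 4, with the structure `C#CC1=Nc2ccccc2C(C)(C)O1`, has not yet been measured. It relates to compound 1 as compound 3 relates to compound 2: the change is hydrogen in place of methyl on a triple-bonded carbon, with the same place word for word, so it is the same change.

With compound 1 giving only a limit and the parallel step unreadable, compound 4 is expected to give 60000 nM, most likely again as a limit, and the step from compound 1 is estimated as a step that the limit leaves unreadable from compound 1 to compound 4. The expected range for compound 4 runs from 30000 nM to 200000 nM.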

Compound 4, half-maximal inhibitory concentration: 5610 nM
Compound 4: the middle estimate sits 11-fold (1.03 log units) above what was measured; the measured number lies below the stated range.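

In this assay, going from prop-1-yn-1-yl to ethynyl on one of the two cores gives an at least 7.1-fold lower number from compound 1 to compound 4 (0.85 log units; beyond the scatter), a step beyond the usual scatter, and since the starting point is a limit of the assay rather than a number, the printed size is a minimum. The same change on the other core, from compound 2 to compound 3, cannot be read, because both of its values are limits, like most of the values in this small set: the limit of > 40000 nM in this assay, at which 3 of the 4 values shown sit. The result therefore shows that hydrogen in place of methyl on a triple-bonded carbon lowered the number on one core, but it does not show that the change carries over to the other core, where a shift of any size, or none, could lie hidden beyond the limit.

As far as these compounds go, it remains open whether the lower number comes from the ethynyl group alone or depends on the core that carries it. From the compounds shown here alone, it is also open whether a longer chain such as ethyl, or an amine, on the triple-bonded carbon would give a number nearer to that of compound 4 or nearer to the limit.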